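This account rests on a few compounds, and the source may have more. Where it says the series, first, only, none or still open, it means among the compounds named here.

Measured compounds in an assay on isolated protein for binding affinity to Leucine-rich repeat serine/threonine-protein kinase 2 (Homo sapiens), read by TR-FRET and LanthaScreen, with a stated time of 2 h; on this read-out lower numbers stand for stronger inhibition and higher numbers for weaker inhibition:
- compound 1 `Cn1c(N2CCCC2)c(C#N)c2c(N)ncnc21` gives 41 nM
- compound 2 `C[C@@H]1CCCN1c1c(C#N)c2c(N)ncnc2n1C` gives 0.4 nM
- compound 3 `Cn1c(-c2ccccc2)c(C#N)c2c(N)ncnc21` gives 30 nM

Compound 2 stands lowest of the three numbers; its nearest neighbour is compound 3, at a 75-fold higher number from compound 2 to compound 3 (1.88 log units; beyond the scatter), and compound 1 lies further off, at a 100-fold lower number from compound 1 to compound 2 (2.01 log units; beyond the scatter) in the reverse direction. The step from compound 1 to compound 3 is a 1.4-fold lower number from compound 1 to compound 3 (0.14 log units; within the scatter).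

Compound 4 `C[C@@H]1CCCN1c1[nH]c2ncnc(N)c2c1C#N` differs from compound 2 in one place: hydrogen in place of methyl on an aromatic nitrogen. Among the compounds with values here, none of the measured steps touches this position. The large step from compound 1 to compound 2 concerns a methyl on a saturated ring carbon, and the steps to compound 3 concern the group on the aromatic carbon; the methyl on the aromatic nitrogen is common to all three measured compounds. Within the data shown here, there is therefore no direct precedent, and the expectation in this assay is a step of no more than the usual scatter, direction unresolved. Compound 4 is expected at 0.8 nM, with a range of 0.2 nM to 4 nM, which amounts to an expected step of a 2.0-fold higher number from compound 2 to compound 4 (0.30 log units; within the scatter).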

Compound 4, inhibition constant: 4 nM
Beside the measured number, compound 4's estimate is 5.0-fold (0.70 log units) below it; the range from low to high includes it.
By their numbers in this assay, from the lowest: compound 2; then compound 4; then compounds 3 and 1 (each within the scatter of the next).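

In this assay, hydrogen in place of methyl on the aromatic nitrogen gives a 10-fold higher number from compound 2 to compound 4 (1.00 log units; beyond the scatter), so this position, held constant across the three earlier compounds, does affect the read-out. Within this single pair, the methyl goes with the lower number, and the step lies beyond the scatter even though the 2-methylpyrrolidin-1-yl group and the nitrile stay unchanged. Nothing available explains why the loss of this one methyl moves the number.

From the compounds shown here alone, whether an ethyl group or a longer chain on the same nitrogen would lower the number further, leave it unchanged or raise it remains open. Going by these compounds, it is also open whether the same change would give a step of similar size with the pyrrolidin-1-yl or phenyl group in place of the 2-methylpyrrolidin-1-yl group.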